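The source may report more compounds than this note shows. Statements on the series, on what has been measured and on what is new or still open speak of the compounds shown alone.

Of the compounds shown here, two have been tested in an assay on HEK293 cells for displacement of a labelled ligand from Neuronal acetylcholine receptor; alpha3/beta4 (Rattus norvegicus), with a stated time of 4 h (on this read-out lower numbers stand for stronger inhibition and higher numbers for weaker inhibition), and neither gave a number. Compound 1, `CO[C@H]1CC[C@H]2CCN(C)[C@H]2C1`, returned only the limit of the assay, recorded for compound 1 as > 300000 nM. Compound 2, `CO[C@H]1CC=C2CCN[C@H]2C1`, likewise reached only the limit, recorded for compound 2 as > 300000 nM. Where compound 2 stands is therefore fixed only by that limit, shared with the other measured value: the limit of > 300000 nM in this assay, at which 2 of the 2 values shown sit. For the measured compounds named here, no step between two measured compounds is available, so nothing shows how far a small change moves the read-out here.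

Compound 3, `O[C@H]1CC=C2CCN[C@H]2C1`, is the next member. It differs from compound 2 by hydrogen in place of methyl on an oxygen on a saturated carbon. With both measured values at the limit, any step from compound 2 to compound 3 is expected to stay hidden, and compound 3 is estimated to sit again at the limit, with a step that the limit leaves unreadable from compound 2 to compound 3 as the expected step. The estimate for compound 3 is 500000 nM, between 100000 nM and 3000000 nM.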

Compound 3, inhibition constant: > 300000 nM
Compound 3 gave a limit, no number; the forecaster's own chance of this, stated with the estimate: 85%; the middle value lies beyond the limit too.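

For the compounds shown here, compound 2 and compound 3 both stand at a limit in this assay, so the change from methoxy to hydroxy gives no step that can be read. The compounds shown leave open whether any member of this series gives a number in this assay at all: the limit of > 300000 nM in this assay, at which 3 of the 3 values shown sit.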